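A few compounds are considered here, and "the series" means these few. Any claim that something is new, unique, unknown or untested is made for them only; others in the source may bear on it.

Working notes on the series. Compound 1 is `CC1(C)[C@@H]2CC[C@@]1(CS(=O)(=O)N1CCN(c3ccc(C(F)(F)F)cn3)CC1)C(N)C2` and in a functional assay on CHO-K1 cells for antagonist activity at C-X-C chemokine receptor type 3 (Homo sapiens), read by FLIPR and calcium flux (on this read-out higher numbers stand for weaker inhibition and lower numbers for stronger inhibition), compound 1 gives 794 nM. Compound 2 is `CC1(C)[C@@H]2CC[C@@]1(CS(=O)(=O)N1CCN(c3ccc(C(F)(F)F)cn3)CC1)C(NS(C)(=O)=O)C2` and in this assay compound 2 gives 631 nM. Only two numbers are in hand, and the step of a 1.3-fold lower number from compound 1 to compound 2 (0.10 log units; within the scatter) lies within the scatter, so on the numbers shown compound 2 and compound 1 cannot be ordered against each other.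

Compound 3 is `CCNC(=O)NC1C[C@H]2CC[C@]1(CS(=O)(=O)N1CCN(c3ccc(C(F)(F)F)cn3)CC1)C2(C)C`. It differs from compound 2 by ethylcarbamoyl in place of methylsulfonyl on an amine nitrogen. Among the compounds with values here, the only measured step that touches this position is a 1.3-fold lower number from compound 1 to compound 2 (0.10 log units; within the scatter), which swapped hydrogen for methylsulfonyl on the same amine nitrogen and moved the number within the scatter. That step tells that the amine nitrogen tolerates a substituent of this size without a shift beyond the scatter, but it does not speak to ethylcarbamoyl as such, so the expectation rests on a single point and is uncertain. The expected step in this assay for the change to compound 3 is a 1.1-fold higher number from compound 2 to compound 3 (0.05 log units; within the scatter), that is, none beyond the scatter. For compound 3 in this assay the estimate is 700 nM, with a range from 250 nM to 2000 nM.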

Compound 3, half-maximal inhibitory concentration: 794 nM
For compound 3 the middle estimate is 1.1-fold (0.05 log units) below the measured one, and the stated range covers the measured number.
By their numbers in this assay, from the lowest: compounds 2, 1 and 3 (each within the scatter of the next).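

Ethylcarbamoyl in place of methylsulfonyl on the amine nitrogen gives a 1.3-fold higher number from compound 2 to compound 3 (0.10 log units; within the scatter) in this assay and, set against the free amine, ethylcarbamoyl in place of hydrogen gives no change at the digits printed from compound 1 to compound 3 (within the scatter) on the same read-out. The position now holds three different occupants, hydrogen, methylsulfonyl and ethylcarbamoyl, and every step among them lies within the scatter, whereas the earlier pair offered only one substituent against hydrogen. The change also brings in a carbonyl and a hydrogen-bond donor in place of the two sulfonyl oxygens, and that exchange comes with no shift beyond the scatter, so in this small set the read-out does not separate these groups on the amine nitrogen. The data on hand offer no measurement that would account for this flat result.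

Still open, on these data alone, is whether a larger occupant of this nitrogen, such as a benzoyl group or a longer chain ending in a carboxylic acid, would move the number beyond the scatter. Also open, as far as these compounds go, is whether the nitrogen itself is needed, which a hydroxyl group on the same saturated ring carbon would test.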